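Swapping a Benzyloxy Arm for Dimethylamino on an Amide Series

The source may hold more compounds than are shown below. What is called first, only, known or untested is meant among the compounds shown, and "the series" means these compounds.

Of the compounds shown here, three sharing one amide-linked core have been measured. Compound 1 `O=C(O)c1cccc(NC(=O)c2ccc(OCc3ccccc3)cc2)c1` carries a benzyloxy group and, in an assay on HeLa cells for agonist activity at Bile acid receptor (Homo sapiens), read by a luciferase reporter (on this read-out lower numbers stand for an effect already at smaller amounts and higher numbers for an effect only at larger amounts of compound), compound 1 gives 9.1 nM. Compound 2 `O=C(O)c1cccc(NC(=O)c2ccc(Oc3ccccc3)cc2)c1` carries phenoxy instead; in this assay compound 2 gives 10 nM. Compound 3 `CC(C)(C)c1ccc(C(=O)Nc2cccc(C(=O)O)c2)cc1` carries tert-butyl, and in this assay compound 3 gives 0.09 nM. Among these three numbers compound 1 stands second highest: the step of a 1.1-fold higher number from compound 1 to compound 2 (0.04 log units; within the scatter) is within the scatter, while a 100-fold lower number from compound 1 to compound 3 (2.00 log units; beyond the scatter) is large, as is a 110-fold lower number from compound 2 to compound 3 (2.05 log units; beyond the scatter).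

The new compound 4 `CN(C)c1ccc(C(=O)Nc2cccc(C(=O)O)c2)cc1` changes compound 1 in one place: dimethylamino in place of benzyloxy on an aromatic carbon. The group that enters is small, like tert-butyl, and unlike the two ring-bearing groups of compound 1 and compound 2. Within the data shown here, the only step that bears directly on it is a 100-fold lower number from compound 1 to compound 3 (2.00 log units; beyond the scatter), where replacing the same benzyloxy with a small group lowered the number greatly. Dimethylamino is not tert-butyl, so the full size of that step is not assumed; a smaller move in the same direction is expected, beyond the scatter. Compound 4 is therefore estimated at 3 nM in this assay, with a range from 0.3 nM to 30 nM, meaning an expected step of a 3.0-fold lower number from compound 1 to compound 4 (0.48 log units; beyond the scatter).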

Compound 4, half-maximal effective concentration: 0.3 nM
The estimate for compound 4 lay 10-fold (1.00 log units) above the measured number; measured number inside the range.
By their numbers in this assay, from the lowest: compound 3; then compound 4; then compounds 1 and 2 (each within the scatter of the next).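

In this assay, dimethylamino gives a 30-fold lower number from compound 1 to compound 4 (1.48 log units; beyond the scatter) and, set against the other ring-bearing group, a 33-fold lower number from compound 2 to compound 4 (1.52 log units; beyond the scatter), so the large shift seen with tert-butyl is no longer a single case: at this aromatic carbon, both groups without a ring give much lower numbers than benzyloxy and phenoxy. The two ringless groups are still not interchangeable, since the change between them gives a 3.3-fold higher number from compound 3 to compound 4 (0.52 log units; beyond the scatter), a modest step that lies beyond the scatter and shows that the identity of the small group matters as well as the absence of a ring. Nothing available here explains why these groups differ.

The compounds shown leave open whether the low numbers belong to small groups in general or only to these two, and a methoxy group, a chlorine atom or a plain methyl group on the same carbon would help separate those possibilities. They also leave open how much a ring itself counts, as opposed to the number of heavy atoms, which a cyclopropyl group or a longer chain such as n-butyl could begin to address.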